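Swapping 3-bromophenyl for 4-bromophenyl

A few compounds are considered here, and "the series" means these few. Any claim that something is new, unique, unknown or untested is made for them only; others in the source may bear on it.

In a functional assay on BGC-823 cells (Homo sapiens) for antiproliferative activity, read by MTT assay, with a stated time of 24 h (a higher number here means a weaker inhibitor, a lower number a stronger inhibitor), compound 1 `Fc1ccccc1CSc1nnc(-c2ccc3c(c2)OCCO3)n1-c1ccccc1` gives 18600 nM and compound 2 `Brc1cccc(CSc2nnc(-c3ccc4c(c3)OCCO4)n2-c2ccccc2)c1` gives 65600 nM as the higher of the two numbers. Compound 3 `Brc1ccc(CSc2nnc(-c3ccc4c(c3)OCCO4)n2-c2ccccc2)cc1` has 4-bromophenyl in place of 3-bromophenyl on a saturated chain carbon bound to a sulfur with the same atoms joined differently. For the measured compounds named here, the one measured step of a 3.5-fold higher number from compound 1 to compound 2 (0.55 log units; beyond the scatter) is modest but beyond the scatter, and it replaced 2-fluorophenyl with 3-bromophenyl, so it bears only loosely on this change. In this assay the expected step of a 1.4-fold lower number from compound 2 to compound 3 (0.14 log units; within the scatter) is slight and no larger than the scatter. Compound 3 is therefore expected at 48000 nM with a range of 16000 nM to 130000 nM as a rough estimate.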

Compound 3, half-maximal inhibitory concentration: 33800 nM
The estimate for compound 3 lay 1.4-fold (0.15 log units) above the measured number, and the stated range covers the measured number.
By their numbers in this assay, from the lowest: compounds 1, 3 and 2 (each within the scatter of the next, the first and the last beyond it).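

In this assay, a 1.9-fold lower number from compound 2 to compound 3 (0.29 log units; within the scatter) stays inside the usual scatter, so at this place, on a saturated chain carbon bound to a sulfur, 3-bromophenyl and 4-bromophenyl cannot be told apart. Likewise, a 1.8-fold higher number from compound 1 to compound 3 (0.26 log units; within the scatter) leaves 4-bromophenyl and 2-fluorophenyl indistinguishable, so only the gap between compound 1 and compound 2 clears the scatter. Nothing measured here offers a reason for these numbers. Still open, from the compounds shown here alone, is whether an amine or a carboxylic acid on this phenyl ring, or a longer chain before it, would shift the number beyond the scatter.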